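From compound 3 to compound 4: a side-group exchange

A few compounds are considered here, and "the series" means these few. Any claim that something is new, unique, unknown or untested is made for them only; others in the source may bear on it.

Measured in a functional assay on the whole organism for agonist activity, with Mus musculus as the target; a higher number here means that more compound is needed for the effect, a lower number that less compound is needed (values below)
- compound 1 `CC(=O)N(C)CC#CCN(C)C` gives 0.97 mg/kg
- compound 2 `COC(=O)N(C)CC#CCN1CCCC1` gives 1.4 mg/kg
- compound 3 `COC(=O)N(C)CC#CCn1ccnc1` gives 2 mg/kg

Compound 3 lies within the scatter of compound 2 and beyond the scatter from compound 1, whose number is lower. Unmeasured compound 4 `COC(=O)N(C)CC#CCN(C)C` differs from compound 3 by dimethylamino in place of 1H-imidazol-1-yl on a saturated chain carbon bound to a triple-bonded carbon, with dimethylamino in place of 1H-imidazol-1-yl. Going by the values given here, one measured step touches this place: a 1.4-fold higher number from compound 2 to compound 3 (0.15 log units; within the scatter), within the scatter. Compound 1 also carries dimethylamino there, differs elsewhere, and gives 0.97 mg/kg. A small shift toward lower numbers is therefore expected, not one beyond the scatter. The estimated move is a 1.7-fold lower number from compound 3 to compound 4 (0.22 log units; within the scatter). For compound 4 the expected value is 1.2 mg/kg (estimated range 0.5 mg/kg to 2.8 mg/kg).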

Compound 4, dose for half-maximal effect: 17.3 mg/kg
For compound 4 the middle estimate is 14-fold (1.16 log units) below the measured one, and the stated range ends below it.
By their numbers in this assay, from the lowest: compounds 1, 2 and 3 (each within the scatter of the next, the first and the last beyond it); then compound 4.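

In this assay, this position on a saturated chain carbon bound to a triple-bonded carbon proves sensitive: dimethylamino in place of 1H-imidazol-1-yl gives an 8.7-fold higher number from compound 3 to compound 4 (0.94 log units; beyond the scatter), and dimethylamino in place of pyrrolidin-1-yl gives a 12-fold higher number from compound 2 to compound 4 (1.09 log units; beyond the scatter), although the two earlier groups stayed within the scatter. The carbonyl carbon also matters, with methoxy in place of methyl giving an 18-fold higher number from compound 1 to compound 4 (1.25 log units; beyond the scatter). No measured evidence accounts for these steps.

Still open, going by these compounds, is whether methoxy in place of methyl gives a similar step with pyrrolidin-1-yl at the chain carbon. Also open, on these data alone, is where piperidin-1-yl or diethylamino would fall there.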